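The source may report more compounds than this note shows. Statements on the series, on what has been measured and on what is new or still open speak of the compounds shown alone.

Measured compounds:
Compound 1, `COc1ccc(CNc2nc([Se]C)nc3ccccc23)cc1`, gives 33000 nM in a functional assay on HTB-54 cells (Homo sapiens) for cytotoxicity, read by MTT assay, with a stated time of 72 h; a higher number here means a weaker inhibitor of growth, a lower number a stronger inhibitor of growth.
Compound 2, `CSc1ccc(CNc2nc([SeH])nc3ccccc23)cc1`, gives 45500 nM in this assay.
Compound 3, `Sc1nc(NCc2ccccc2)c2ccccc2n1`, gives 15200 nM in this assay.

On these three numbers compound 3 stands lowest, and its gap to each of the other two lies beyond the usual scatter, so it is the strongest growth inhibitor of the group. Compound 4, `CSc1nc(NCc2ccccc2)c2ccccc2n1`, has not yet been measured. It differs from compound 3 in one place: methyl in place of hydrogen on a sulfur. Among the compounds with values here, no pair of measured compounds shows this exact change, so nothing in the data fixes its size or direction. A small step, not clearly beyond the scatter, is expected, with the number for compound 4 leaning slightly higher. Compound 4 is therefore estimated at 20000 nM, with a range from 8000 nM to 50000 nM, which means an expected step of a 1.3-fold higher number from compound 3 to compound 4 (0.12 log units; within the scatter).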

Compound 4, concentration for 50% growth inhibition: 37900 nM
The estimate for compound 4 lay 1.9-fold (0.28 log units) below the measured number; the measured number falls inside the stated range.
By their numbers in this assay, from the lowest: compound 3; then compounds 1, 4 and 2 (each within the scatter of the next).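

Putting methyl in place of hydrogen on this sulfur gives a 2.5-fold higher number from compound 3 to compound 4 (0.40 log units; beyond the scatter) in this assay, so this position is not indifferent to a change of a single heavy atom. In this one pair, the form with the hydrogen on sulfur is the stronger inhibitor of growth, though the step is modest. Nothing measured here explains the step. Still open, going by these compounds, is whether a longer chain such as ethyl on the sulfur would raise the number further. On these data alone, an amine in place of the sulfur group is equally open.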